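A few compounds are considered here, and "the series" means these few. Any claim that something is new, unique, unknown or untested is made for them only; others in the source may bear on it.

In a functional assay on 1A9 cells (Homo sapiens) for antiproliferative activity, read by sulforhodamine B assay, with a stated time of 3 days (on this read-out higher numbers stand for an effect only at larger amounts of compound and lower numbers for an effect already at smaller amounts), compound 1 `CCCC1=C(OC)C(CCC)(CCC)C(=O)/C(=C(O)\C=C\c2ccccc2)C1=O` gives 3.7 uM. Compound 2 `CCCC1=C(OC)C(CCC)(CCC)C(=O)/C(=C(O)\C=C\c2ccc(I)cc2)C1=O` gives 1.8 uM, the lower of the two numbers available. For compound 3 `CCCCOC1=C(CCC)C(=O)/C(=C(O)/C=C/c2ccccc2)C(=O)C1(CCC)CCC` the result is "not determined" (no result reported), so it offers no guidance here. The next compound to be tested is compound 4 `CCCC1=C(OC)C(CCC)(CCC)C(=O)/C(=C(O)\C=C\c2ccc(Br)cc2)C1=O`, which differs from compound 2 by a single swap on an aromatic carbon, para to a large group, with bromo in place of iodo on an aromatic carbon.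

For the measured compounds named here, only one measured step bears on this swap: a 2.1-fold lower number from compound 1 to compound 2 (0.31 log units; beyond the scatter), where iodo replaced hydrogen on that same carbon. That step is modest, although it lies beyond the scatter. Going by the values given here, no measured compound carries bromo, so this is indirect evidence. Even the full change from hydrogen to iodo moved the number only slightly, so exchanging iodo for bromo should move it less. The expected result in this assay is a 1.2-fold higher number from compound 2 to compound 4 (0.09 log units; within the scatter), a small upward drift that stays within the scatter. For compound 4 the estimated value is 2.2 uM, with an expected range from 1.1 uM to 4.5 uM.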

Compound 4, concentration for half-maximal effect: 1.9 uM
Compound 4: middle estimate off by 1.2-fold (0.06 log units), on the high side, and the stated range covers the measured number.
By their numbers in this assay, from the lowest: compounds 2, 4 and 1 (each within the scatter of the next, the first and the last beyond it).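

Exchanging 4-iodophenyl for 4-bromophenyl makes no clear difference in this assay, with a 1.1-fold higher number from compound 2 to compound 4 (0.02 log units; within the scatter), so at this position iodo holds no measurable edge over bromo. Measured against hydrogen, bromo gives a 1.9-fold lower number from compound 1 to compound 4 (0.29 log units; within the scatter), while iodo gives a 2.1-fold lower number from compound 1 to compound 2 (0.31 log units; beyond the scatter), and these two steps are close in size even though only the iodo step clears the scatter, so only compound 2 is clearly separated from compound 1. Nothing available explains why the two halogens behave so much alike.

Still open, going by these compounds, is whether a halogen is needed here at all, or whether chloro, an amine or a carboxylic acid on the same carbon would leave the number unchanged or shift it. On these data alone, compound 3 has no number, so the effect of its longer butoxy chain on the shared core also remains unknown.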